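The source may hold more compounds than are shown below. What is called first, only, known or untested is meant among the compounds shown, and "the series" means these compounds.

Going by the values given here, in a functional assay for inhibition, with Homo sapiens as the target (on this read-out lower numbers stand for stronger inhibition and higher numbers for weaker inhibition), compound 2 `CC#CCC(C)[C@H](O)/C=C/[C@H]1[C@H](O)C[C@]2(C#CCCCN=[N+]=[N-])C/C(=C\CCCC(=O)O)C[C@H]12` gives 20 nM, the stronger inhibition of the two compounds measured so far, while compound 1 `CC#CCC(C)[C@H](O)/C=C/[C@H]1[C@H](O)C[C@]2(C#CCCCI)C/C(=C/CCCC(=O)O)C[C@H]12` gives 200 nM. Compound 3 `CC#CCC(C)[C@H](O)/C=C/[C@H]1[C@H](O)C[C@]2(C#CCCCN=[N+]=[N-])C/C(=C/CCCC(=O)O)C[C@H]12` is a close relative of compound 2: the two compounds have the same atoms and bonds; at least one stereo element is drawn with a configuration in one of them and without one in the other: 1 of 9 stereo elements differ; a double bond is drawn Z in compound 2 and E in compound 3. Among the compounds with values here, no pair of measured compounds isolates this change, so its size in this assay remains uncertain. A small move toward stronger inhibition, within or only slightly beyond the scatter, is expected, although a move the other way cannot be excluded. The expected step is a 2.0-fold lower number from compound 2 to compound 3 (0.30 log units; within the scatter). Compound 3 is estimated at 10 nM, with an expected range of 2 nM to 80 nM.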

Compound 3, half-maximal inhibitory concentration: 850 nM
The estimate for compound 3 lay 85-fold (1.93 log units) below the measured number; measured number above the stated range.
By their numbers in this assay, from the lowest: compound 2; then compound 1; then compound 3.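

In this assay, the double-bond geometry alone makes a large difference with atoms and bonds unchanged (a 43-fold higher number from compound 2 to compound 3 (1.63 log units; beyond the scatter)). With the double bond drawn the same way, azido in place of iodo on a saturated chain carbon gives only a modest change (a 4.3-fold higher number from compound 1 to compound 3 (0.63 log units; beyond the scatter)), so the gap between compounds 1 and 2 cannot be credited to azido alone. One caution applies to reading the larger step as a clean geometry effect: the fact that one of compounds 2 and 3 is drawn with a defined configuration and the other without, at the place where they differ. Still open, from the compounds shown here alone, is how iodo behaves with the double bond drawn Z, and whether an amine in place of azido would keep the inhibition.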